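Swapping diethylamino for tert-butylamino on the side chain

The source may hold more compounds than are shown below. What is called first, only, known or untested is meant among the compounds shown, and "the series" means these compounds.

Values in a functional assay on MCF7 cells (Homo sapiens) for antiproliferative activity (a higher number here means a weaker inhibitor, a lower number a stronger inhibitor), are as follows
Compound 1 `CC(=O)Oc1ccc(C(=O)Nc2cc3ccc(OCC4CCCNC4)c(C)c3oc2=O)cc1CC=C(C)C` gives 820 nM
Compound 2 `CC(C)=CCc1cc(C(=O)Nc2cc3ccc(OCCCN4CCCCC4)c(C)c3oc2=O)ccc1O` gives > 50000 nM as a limit of the assay, not a number
Compound 3 `CCN(CC)CCCOc1ccc2cc(NC(=O)c3ccc(O)c(CC=C(C)C)c3)c(=O)oc2c1C` gives 6390 nM

Of the two true numbers, compound 3 holds the higher one, with 6390 nM against compound 1 at 820 nM in this comparison. Compound 4 `CC(C)=CCc1cc(C(=O)Nc2cc3ccc(OCCCNC(C)(C)C)c(C)c3oc2=O)ccc1O` differs from compound 3 in one place, (tert-butyl)amino in place of diethylamino on a saturated chain carbon, three bonds along the chain from an oxygen on an aromatic ring with (tert-butyl)amino in place of diethylamino on a saturated chain carbon, three bonds along the chain from an oxygen on an aromatic ring. Within the data shown here, one measured step bears on that place, an at least 7.8-fold lower number from compound 2 to compound 3 (0.89 log units; beyond the scatter) where diethylamino replaced piperidin-1-yl. That step shows the number can move at this place, but it involves a different exchange and gives no direction for this one. A step beyond the scatter is therefore not specifically expected, though a sizeable move either way remains possible. The estimate amounts to a 1.3-fold higher number from compound 3 to compound 4 (0.10 log units; within the scatter) as the expected step. Compound 4 is estimated at 8000 nM with an expected range of 2000 nM to 35000 nM in this assay when measured.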

Compound 4, half-maximal inhibitory concentration: 950 nM
Compound 4: the middle estimate sits 8.4-fold (0.93 log units) above what was measured; measured number below the stated range.
By their numbers in this assay, from the lowest: compounds 1 and 4 (each within the scatter of the next); then compound 3. At a limit, above all of these: compound 2.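

In this assay, (tert-butyl)amino in place of diethylamino, on a saturated chain carbon three bonds along the chain from an oxygen on an aromatic ring, gives a 6.7-fold lower number from compound 3 to compound 4 (0.83 log units; beyond the scatter), so this place responds to how the same atoms are joined, not only to which atoms are present. The exchange of piperidin-1-yl for (tert-butyl)amino at the same place gives an at least 52-fold lower number from compound 2 to compound 4 (1.72 log units; beyond the scatter), a step read against a limit. The value of compound 2 is a limit of the assay and not a number: the limit of > 50000 nM in this assay, at which 1 of the 4 values shown sits.

The compounds shown do not separate the hydrogen-bond donor that (tert-butyl)amino carries from the arrangement of its carbons. Isopropylamino on the same chain would add a further case, as would a plain primary amine.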